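Aminopyrimidine imines: cyclopentyl to isopropyl on the amine

The compounds below may be only part of what the source reports. "The series", "measured", "known", "first", "only" and "open" are said of these compounds alone.

Measured so far in a functional assay on HT-29 cells (Homo sapiens) for antiproliferative activity, read by MTT assay; on this read-out higher numbers stand for weaker inhibition and lower numbers for stronger inhibition:
compound 1, `CN1CCN(c2ccc(Nc3ncc(/N=C/c4ccccc4)c(NC4CCCC4)n3)cc2)CC1`, 28600 nM
compound 2, `CN1CCN(c2ccc(Nc3ncc(/N=C/c4cccs4)c(NC4CCCC4)n3)cc2)CC1`, 21700 nM
compound 3, `NS(=O)(=O)c1ccc(Nc2ncc(/N=C/c3cccs3)c(NC3CCCC3)n2)cc1`, 9950 nM

Compound 2 stands second highest of the three numbers. Its nearest neighbour is compound 1; the step of a 1.3-fold lower number from compound 1 to compound 2 (0.12 log units; within the scatter) is within the scatter, so the two values cannot be ordered. The step of a 2.2-fold lower number from compound 2 to compound 3 (0.34 log units; beyond the scatter) is beyond the scatter, and compound 3 gives the lowest number of the three.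

Compound 4, `CC(C)Nc1nc(Nc2ccc(N3CCN(C)CC3)cc2)ncc1/N=C/c1cccs1`, has not been measured. It differs from compound 2 in one place: isopropyl in place of cyclopentyl on a nitrogen on an aromatic ring. Neither measured step touches this part of the molecule. The step from compound 1 to compound 2 concerns the group on the carbon with a double bond to nitrogen, and the step from compound 2 to compound 3 concerns the group on the aromatic carbon of the aniline; both were small or modest. The amine substituent has no measured comparison at all, so the change is judged only as a shortening of the alkyl group, from a five-membered non-aromatic ring to a three-carbon chain, with donors and acceptors unchanged.

With nothing bearing directly on it, the expected step of a 1.2-fold higher number from compound 2 to compound 4 (0.06 log units; within the scatter) is none beyond the scatter. Compound 4 is therefore estimated at 25000 nM in this assay, with a range from 9000 nM to 70000 nM.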

Compound 4, half-maximal inhibitory concentration: > 100000 nM
Compound 4 gave a limit, no number; the forecaster's own chance of this, stated with the estimate: 10%; middle value at least 4.0-fold (0.60 log units) away from the limit.
By their numbers in this assay, from the lowest: compound 3; then compounds 2 and 1 (each within the scatter of the next). At a limit, above all of these: compound 4.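

In this assay compound 4 gives > 100000 nM, which is a limit of the assay and not a number: the limit of > 100000 nM in this assay, at which 1 of the 4 values shown sits.

Among these compounds, the change from cyclopentyl to isopropyl on the nitrogen gives an at least 4.6-fold higher number from compound 2 to compound 4 (0.66 log units; beyond the scatter), the first measured comparison at this position, and it shows that the amine substituent is not a neutral place. The earlier steps at the other two places were smaller in their printed sizes, with a 1.3-fold lower number from compound 1 to compound 2 (0.12 log units; within the scatter) and a 2.2-fold lower number from compound 2 to compound 3 (0.34 log units; beyond the scatter), so on the compounds shown this position has the largest effect on the read-out, although the true size of the step stays unknown behind the limit.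

The compounds shown leave open whether the loss goes with the ring or with the number of carbons, a question that a cyclohexyl group or an open pentyl chain on the same nitrogen would address. They also leave open whether the isopropylamino change has the same effect with sulfamoyl on the aromatic carbon, as in compound 3, or with a phenyl group in place of the thiophen-2-yl, as in compound 1.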